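Does Flipping One Stereocentre Change the Removal Rate?

A few compounds are considered here, and "the series" means these few. Any claim that something is new, unique, unknown or untested is made for them only; others in the source may bear on it.

Measured in an ADME assay (liver) for metabolic stability, with Liver microsome (Rattus norvegicus) as the target, using microsomes and NADPH, with a stated time of 30 min, at 37 degrees C, tested at 1 uM; a lower number here means slower removal, a higher number faster removal of the compound:
- compound 1 `CC(O)(c1ccc(-c2ccc(S(=O)(=O)c3ccc(N)nc3)nc2Oc2ccccc2)nc1)C(F)(F)F`: 213 mL.min-1.g-1
- compound 2 `CC(O)(c1ccc(-c2ncc(S(=O)(=O)c3ccc(N)nc3)s2)c(Cl)c1)C(F)(F)F`: < 14 mL.min-1.g-1 (a limit)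
- compound 3 `C[C@@](O)(c1ccc(-c2ncc(S(=O)(=O)c3ccc(N)nc3)s2)c(Cl)c1)C(F)(F)F`: < 14 mL.min-1.g-1 (a limit)

Compound 3 gives < 14 mL.min-1.g-1 in this assay, which is a limit and not a number. Compound 4 `C[C@](O)(c1ccc(-c2ncc(S(=O)(=O)c3ccc(N)nc3)s2)c(Cl)c1)C(F)(F)F` has the same atoms and bonds, and the only difference is its drawn configuration: the two compounds have the same atoms and bonds and differ only in configuration as drawn: 1 of 1 stereo elements differ; a stereocentre at a saturated chain carbon is drawn R in compound 3 and S in compound 4. Within the data shown here, the one measured step that bears on this is a step that the two limits leave unreadable from compound 2 to compound 3, so it offers no size to carry over. Compound 1 differs from compound 3 by more than one change and gives no guide here. Among the measured compounds shown here, with the limit of < 14 mL.min-1.g-1 in this assay, at which 2 of the 3 values shown sit, as the only evidence, no shift beyond the usual scatter is expected. The expected step is a step that the limit leaves unreadable from compound 3 to compound 4. For compound 4 the estimated value is 12 mL.min-1.g-1, with an expected range of 7 mL.min-1.g-1 to 25 mL.min-1.g-1.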

Compound 4, intrinsic clearance in microsomes: < 14 mL.min-1.g-1
Compound 4: no number, only a limit (the forecaster's own chance of this, stated with the estimate: 75%); the middle value is on the limit's open side.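

Among these compounds, no step among compound 2, compound 3 and compound 4 can be read: in this assay each gives only a limit. From the compounds shown here alone, whether compound 3 and compound 4 truly differ in removal rate, and by how much, stays open.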